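Notes: 4-(tert-butoxycarbonyl)butyl to 3-(tert-butoxycarbonyl)propyl

A few compounds are considered here, and "the series" means these few. Any claim that something is new, unique, unknown or untested is made for them only; others in the source may bear on it.

In a functional assay (strain AB) with Danio rerio as the target, read by microscopy, with a stated time of 1 h (on this read-out higher numbers stand for an effect only at larger amounts of compound and lower numbers for an effect already at smaller amounts), compound 1 (`CCC1CCc2c(sc(NC(=O)Nc3ccc(Cl)cc3)c2C(N)=O)C1`) gives > 25000 nM as a limit of the assay and not a number.

Compound 3 (`CCN1CCc2c(sc(NC(=S)Nc3ccc(Cl)cc3)c2C(N)=O)C1`) gives 6570 nM in this assay as a measured number. Compound 2 (`CC(C)(C)OC(=O)CCCC[N+]1(C)CCc2c(sc(NC(=O)Nc3ccc(Cl)cc3)c2C(N)=O)C1`) gives 140 nM and holds the lower of the two numbers, with compound 3 higher by a gap beyond the scatter.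

Compound 4 (`CC(C)(C)OC(=O)CCC[N+]1(C)CCc2c(sc(NC(=O)Nc3ccc(Cl)cc3)c2C(N)=O)C1`) has tert-butoxycarbonyl in place of (tert-butoxycarbonyl)methyl on a saturated chain carbon, three bonds along the chain from an amine nitrogen in a ring. The same difference reads 4-(tert-butoxycarbonyl)butyl to 3-(tert-butoxycarbonyl)propyl.

Within the data shown here, no measured pair here differs in one place only, so the size of this step is a judgement. The expectation starts from compound 2 at 140 nM and is a modest rise in the number, near the edge of the scatter. The estimated change is a 2.0-fold higher number from compound 2 to compound 4 (0.30 log units; within the scatter) on this reading. Compound 4 is estimated at 280 nM with an expected range from 80 nM to 1100 nM in this assay.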

Compound 4, half-maximal effective concentration: 250 nM
The estimate for compound 4 lay 1.1-fold (0.05 log units) above the measured number, and the stated range covers the measured number.
By their numbers in this assay, from the lowest: compounds 2 and 4 (each within the scatter of the next); then compound 3. At a limit, above all of these: compound 1.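

Among these compounds, the change from 4-(tert-butoxycarbonyl)butyl to 3-(tert-butoxycarbonyl)propyl gives the first comparison that differs in one place only: in this assay, it is a 1.8-fold higher number from compound 2 to compound 4 (0.25 log units; within the scatter). Removing this one chain unit therefore leaves the two compounds indistinguishable in this assay, so the shorter ester chain is tolerated at this position, on a saturated chain carbon, three bonds along the chain from an amine nitrogen in a ring. Nothing among the measurements given here accounts for this small step.

Still open, from the compounds shown here alone, is whether the tolerance holds for a shorter 2-(tert-butoxycarbonyl)ethyl or (tert-butoxycarbonyl)methyl chain, or for a longer chain. Going by these compounds, it is equally open whether the tert-butyl ester itself matters, or whether a free carboxylic acid, a primary amide or a plain alkyl chain at this position would give a similar number.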